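A smaller group on the core of compound 1

A few compounds are considered here, and "the series" means these few. Any claim that something is new, unique, unknown or untested is made for them only; others in the source may bear on it.

Compound 1 `O=C1O[C@H]([C@@H](O)Cn2cc(-c3ccc(Br)cc3)nn2)C(OCc2ccccc2)=C1OCc1ccccc1` is tested in a functional assay on HeLa cells (Homo sapiens) for antiproliferative activity, read by MTT assay, with a stated time of 72 h (a higher number here means a weaker inhibitor, a lower number a stronger inhibitor), where compound 1 gives 3910 nM. Within the data shown here, that is the only number among the three values shown for this assay. Compound 2 `CC(C)(C)OC(=O)N1CCN(C(=S)SCc2cn(C[C@H](O)[C@H]3OC(=O)C(OCc4ccccc4)=C3OCc3ccccc3)nn2)CC1` reaches only a limit, > 100000 nM in this assay. Compound 3 `O=C1O/C(=C\Cn2cc(-c3cc(C(F)(F)F)cc(C(F)(F)F)c3)nn2)C(OCc2ccccc2)=C1OCc1ccccc1` likewise reaches only a limit, > 100000 nM in this assay. Two of the three values thus sit at the limit of > 100000 nM in this assay, at which 2 of the 3 values shown sit. Compound 4 `C[Si](C)(C)c1cn(C[C@H](O)[C@H]2OC(=O)C(OCc3ccccc3)=C2OCc2ccccc2)nn1` differs from compound 1 by a group of 4 heavy atoms (3 carbon, 1 silicon; no ring) in place of a group of 7 heavy atoms (6 carbon, 1 bromine; one six-membered aromatic ring of carbon only), on an aromatic carbon. Among the measured compounds shown here, no measured pair differing in one place is available, so the size of this step is uncertain; a weakening beyond the scatter is expected. Compound 4 is expected to give 15000 nM, between 4000 nM and 60000 nM, a step of a 3.8-fold higher number from compound 1 to compound 4 (0.58 log units; beyond the scatter).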

Compound 4, half-maximal inhibitory concentration: 22300 nM
Compound 4: middle estimate off by 1.5-fold (0.17 log units), on the low side; the range from low to high includes it.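

On the aromatic carbon of the five-membered aromatic ring with 3 nitrogen, replacing 4-bromophenyl with the group of 3 carbon and 1 silicon gives a 5.7-fold higher number from compound 1 to compound 4 (0.76 log units; beyond the scatter) in this assay. Among these compounds, this is the first readable step at this position, and it shows that a number can still be obtained there without any ring on that carbon, though a weaker one. Compound 4 gives a number and does not reach the limit: the limit of > 100000 nM in this assay, at which 2 of the 4 values shown sit.

From the compounds shown here alone, whether the bromine or the phenyl ring carries the difference stays open. So does where an unsubstituted phenyl, a butyl chain or an amine on this carbon would fall relative to compound 1 and compound 4.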